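Fluoro to methoxy on the pendant phenyl of compound 2

The source may report more compounds than this note shows. Statements on the series, on what has been measured and on what is new or still open speak of the compounds shown alone.

Of the compounds shown here, two have numbers so far. For the measured compounds named here, compound 1 `COc1ccc(C2=NN(C3=NC(c4ccccc4)CS3)C(c3cccc4ccccc34)C2)cc1` and compound 2 `Fc1ccc(C2=NN(C3=NC(c4ccccc4)CS3)C(c3ccc4ccccc4c3)C2)cc1` share the same core and differ in two places, the substituent on the pendant phenyl and the point of attachment of the naphthyl, so no single step connects them. In a functional assay on HeLa cells (Homo sapiens) for inhibition, read by CCK-8 assay, with a stated time of 48 h (on this read-out higher numbers stand for weaker inhibition and lower numbers for stronger inhibition), compound 1 gives 3310 nM. In this assay compound 2 gives 9730 nM, the highest of the two numbers; the gap to compound 1 is beyond the scatter, but with two differences between them it cannot be assigned to either one.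

Compound 3 `COc1ccc(C2=NN(C3=NC(c4ccccc4)CS3)C(c3ccc4ccccc4c3)C2)cc1` is the next point. It keeps the naphthyl attachment of compound 2 and changes only the pendant phenyl: methoxy in place of fluoro on an aromatic carbon. This makes compound 3 the single-change neighbour of both compound 2 and compound 1, so its number will split the two-place gap.

Going by the values given here, no directly measured step of this kind exists. The expectation is a modest move toward the number of compound 1 3310 nM, with the step of a 1.8-fold lower number from compound 2 to compound 3 (0.25 log units; within the scatter) estimated as small and possibly within the scatter. Compound 3 is estimated at 5500 nM, within the range 2200 nM to 14000 nM.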

Compound 3, half-maximal inhibitory concentration: 1860 nM
Estimate against measurement, compound 3: 3.0-fold (0.47 log units) above; measured number below the stated range.
By their numbers in this assay, from the lowest: compounds 3 and 1 (each within the scatter of the next); then compound 2.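

In this assay, the pendant phenyl is now the position with a change that reads beyond the scatter: going from 4-fluorophenyl to 4-methoxyphenyl, with naphthalen-2-yl held constant, gives a 5.2-fold lower number from compound 2 to compound 3 (0.72 log units; beyond the scatter) as the measured step. With methoxy held on the phenyl, replacing naphthalen-1-yl with naphthalen-2-yl gives a 1.8-fold lower number from compound 1 to compound 3 (0.25 log units; within the scatter) and stays within the scatter, so the naphthyl attachment point shows no separable effect in this pair. The data offer no measured basis for explaining either step.

The compounds shown leave open whether the methoxy step also holds with naphthalen-1-yl, since the fluoro partner for that comparison is absent from this set. They also do not separate the contribution of the oxygen from that of the added carbon, which a hydroxyl or an ethyl on the same aromatic carbon could address, while an amine or a carboxylic acid there would test how far this position tolerates other groups.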